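A few compounds are considered here, and "the series" means these few. Any claim that something is new, unique, unknown or untested is made for them only; others in the source may bear on it.

Measured so far in an assay on isolated protein for inhibition of serine protease 1 (Homo sapiens); a lower number here means a stronger inhibitor, a higher number a weaker inhibitor:
- compound 1 `CC(C)(C)c1ccc(C(=O)NCCCc2cc(C(=N)N)ccc2O)cc1`: 2200 nM
- compound 2 `N=C(N)c1ccc(O)c(/C=C/CNC(=O)c2ccc(-c3cccc(C(N)=O)c3)cc2)c1`: > 2900 nM, a limit of the assay, not a number
- compound 3 `N=C(N)c1ccc(O)c(/C=C/CNC(=O)c2ccc(-c3ccc(C(N)=O)cc3)cc2)c1`: 1400 nM

Compound 3 holds the lowest of the two numbers shown; compound 1 sits close to it, within the scatter, so no order between the two can be claimed. For compound 2 only the limit is known (the limit of > 2900 nM in this assay, at which 1 of the 3 values shown sits).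

Among the compounds with values here, the one step measured along this series runs an at least 2.0-fold lower number from compound 2 to compound 3 (0.31 log units; beyond the scatter), a modest gain for moving the carbamoyl group round the outer ring.

Compound 4 `N=C(N)c1ccc(O)c(/C=C/CNC(=O)c2ccc(-c3ccnc(C(N)=O)c3)cc2)c1` keeps the shared core of compound 3 and differs only at the outer ring: 2-carbamoylpyridin-4-yl in place of 4-carbamoylphenyl on an aromatic carbon. Within the data shown here, the carbamoyl group stays on the ring and the ring keeps its size; only one ring carbon becomes nitrogen. Among the measured compounds shown here, no measured step in this assay covers such a swap, and the step from compound 2 to compound 3 speaks to position rather than to ring type, so little change is expected. Compound 4 is estimated at 1400 nM, between 600 nM and 3000 nM, which means an expected step of no change at the digits printed from compound 3 to compound 4 (within the scatter), within the scatter.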

Compound 4, inhibition constant: 2200 nM
The estimate for compound 4 lay 1.6-fold (0.20 log units) below the measured number; the range from low to high includes it.
By their numbers in this assay, from the lowest: compounds 3, 1 and 4 (each within the scatter of the next). At a limit, above all of these: compound 2.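

The earlier step spoke only to where the carbamoyl group stands on the outer ring; this change tests the ring itself, and in this assay replacing one ring carbon with nitrogen gives no readable difference: a 1.6-fold higher number from compound 3 to compound 4 (0.20 log units; within the scatter). The 2-carbamoylpyridin-4-yl and 4-carbamoylphenyl groups therefore cannot be separated on these data, while the second new step, an at least 1.3-fold lower number from compound 2 to compound 4 (0.11 log units; that floor lies within the scatter), supports no order between those two compounds. Compound 2 still carries only a limit of the assay, not a number: the limit of > 2900 nM in this assay, at which 1 of the 4 values shown sits.

Going by these compounds, whether the carbamoyl group itself is needed stays open, and a carboxylic acid or a nitrile in its place on the same outer ring would address that. Also open, on these data alone, is how an outer ring with its nitrogen at another ring position would read in this assay.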